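The source may hold more compounds than are shown below. What is called first, only, known or untested is meant among the compounds shown, and "the series" means these compounds.

Measured in a functional assay on PBMC cells (Homo sapiens) for inhibition, with a stated time of 24 h; on this read-out lower numbers stand for stronger inhibition and higher numbers for weaker inhibition:
- compound 1 `Cc1cc(-c2ccnc3[nH]nc(C(F)(F)F)c23)cc(C2(CN)CCC2)c1`: 60 nM
- compound 2 `NCC1(c2cccc(-c3ccnc4[nH]nc(C(F)(F)F)c34)c2)CCC1`: 90 nM

Compound 1 stands level with compound 2 within the scatter, with a 1.5-fold higher number from compound 1 to compound 2 (0.18 log units; within the scatter). Compound 3 `Cc1cc(-c2ccnc3[nH]nc(C(F)(F)F)c23)cc(C2(CN)COC2)c1` is not yet measured, and its difference is 3-(aminomethyl)oxetan-3-yl in place of 1-(aminomethyl)cyclobutyl on an aromatic carbon. Among the measured compounds shown here, the only measured step, a 1.5-fold higher number from compound 1 to compound 2 (0.18 log units; within the scatter), is a hydrogen in place of a methyl group and leaves the 1-(aminomethyl)cyclobutyl untouched, so it bears only weakly on this change. For the measured compounds named here, no measured step covers this exchange, so only a modest move in this assay toward weaker inhibition is expected, near the edge of the scatter. The expected step is a 1.8-fold higher number from compound 1 to compound 3 (0.26 log units; within the scatter). For compound 3 the estimate is 110 nM, with an expected range of 35 nM to 350 nM.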

Compound 3, half-maximal inhibitory concentration: 450 nM
For compound 3 the middle estimate is 4.1-fold (0.61 log units) below the measured one; the measured number lies above the stated range.
By their numbers in this assay, from the lowest: compounds 1 and 2 (each within the scatter of the next); then compound 3.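

In this assay, the four-membered ring at this position is not a neutral place to change: 3-(aminomethyl)oxetan-3-yl in place of 1-(aminomethyl)cyclobutyl gives a 7.5-fold higher number from compound 1 to compound 3 (0.88 log units; beyond the scatter). Among the compounds shown here, the oxygen exchange is thus the first single change to move the number beyond the scatter, whereas the methyl-to-hydrogen step stayed within it. No measurement here bears on what lies behind this shift. Open, on these data alone, is whether an azetidine ring nitrogen or a cyclopentyl ring would stay nearer compound 1, and whether the oxetane exchange has a similar effect without the aromatic methyl group.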